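The compounds below may be only part of what the source reports. "The series", "measured", "known", "first", "only" and "open" are said of these compounds alone.

In a functional assay on FM3A cells (Mus musculus) for antiproliferative activity, with a stated time of 48 h (a higher number here means a weaker inhibitor, a lower number a stronger inhibitor), compound 1 (`C=C(Br)C(=O)Nc1ccc(C(=O)/C=C/c2ccccc2)cc1`) gives 690 nM while compound 2 (`C=C(Br)C(=O)Nc1ccc(C(=O)/C=C/c2ccc(OC)cc2)cc1`) gives 1000 nM and compound 3 (`C=C(Br)C(=O)Nc1ccc(C(=O)/C=C/c2ccccc2OC)cc1`) gives 370 nM on the same read-out. Compound 2 cannot be told apart from compound 1, with a 1.4-fold higher number from compound 1 to compound 2 (0.16 log units; within the scatter) between them, but it does separate from compound 3, with a 2.7-fold lower number from compound 2 to compound 3 (0.43 log units; beyond the scatter) as the gap between them.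

The next structure is compound 4 (`C=C(Br)C(=O)Nc1ccc(C(=O)/C=C/c2ccc(OC)c(OC)c2)cc1`). Its change from compound 2 (methoxy in place of hydrogen on an aromatic carbon) is methoxy in place of hydrogen on an aromatic carbon, ortho to a methoxy group and meta to a large group.

Two measured steps are the same kind of replacement, both made on compound 1. They are a 1.4-fold higher number from compound 1 to compound 2 (0.16 log units; within the scatter) as the first and a 1.9-fold lower number from compound 1 to compound 3 (0.27 log units; within the scatter) as the second. Both stay within the scatter and they run in opposite directions. For the measured compounds named here, the one step beyond the scatter moves a methoxy rather than adding one, so it bears less directly. Going by the values given here, no measured compound carries two methoxy groups, so this remains an extrapolation.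

No step beyond the scatter is therefore expected in this assay for this change. The expected step is a 1.3-fold lower number from compound 2 to compound 4 (0.10 log units; within the scatter) and no more than that. Compound 4 is estimated at 800 nM with an expected range of 300 nM to 2000 nM on this read-out.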

Compound 4, half-maximal inhibitory concentration: 1200 nM
Compound 4: middle estimate off by 1.5-fold (0.18 log units), on the low side; low and high end bracket the measured number.
By their numbers in this assay, from the lowest: compounds 3, 1, 2 and 4 (each within the scatter of the next, the first and the last beyond it).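

A second methoxy on the compound 2 core, ortho to a methoxy group and meta to a large group, gives a 1.2-fold higher number from compound 2 to compound 4 (0.08 log units; within the scatter) in this assay, so this position accepts the added group without a readable shift on this read-out. Compound 4 is the only compound shown with two methoxy groups, and with it the replacement of hydrogen by methoxy has been read on a second core, where it again stays within the scatter. The size of the change does not separate between the two cores either: the same change on two cores in this assay, a 1.9-fold lower number (0.27 log units; within the scatter) from compound 1 to compound 3 and a 1.2-fold higher number (0.08 log units; within the scatter) from compound 2 to compound 4, 2.2-fold (0.35 log units) apart, within the scatter of two such steps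

The compounds shown leave open whether this position responds to anything other than methoxy, such as a hydroxy group, an amine, a carboxylic acid or a longer chain in its place, since a single group cannot show how far the tolerance extends. Going by these compounds, it also remains open whether a further methoxy on compound 3, which carries the lowest number of the series at 370 nM, would stay within the scatter as it does on compound 2.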